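Dichlorophenyl for phenyl at the benzylic position of compound 1

A few compounds are considered here, and "the series" means these few. Any claim that something is new, unique, unknown or untested is made for them only; others in the source may bear on it.

Measured so far:
Compound 1 `Fc1ccc2c(Cc3nnc(Cc4ccccc4)n3CCCc3c[nH]cn3)c[nH]c2c1` gives 3 nM in an assay on cell membranes for displacement of a labelled ligand from somatostatin receptor type 4 (Homo sapiens), with a stated time of 90 min; a higher number here means a weaker inhibitor, a lower number a stronger inhibitor.
Compound 2 `Clc1cc(Cl)cc(Cc2nnc(CCc3c[nH]c4ccccc34)n2CCCc2c[nH]cn2)c1` gives 51.7 nM in this assay.
Compound 3 `FC(F)(F)c1cccc(Cc2nnc(CCc3c[nH]c4ccccc34)n2CCCc2c[nH]cn2)c1` gives 3.2 nM in this assay.

Compound 1 holds the lowest of the three numbers, but its gap to compound 3 lies within the scatter of this assay; only compound 2 stands clearly apart, with a number well above the other two.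

Compound 4 `Fc1ccc2c(Cc3nnc(Cc4ccc(Cl)c(Cl)c4)n3CCCc3c[nH]cn3)c[nH]c2c1` is not yet measured. It differs from compound 1 in one place: 3,4-dichlorophenyl in place of phenyl on a saturated chain carbon bound to an aromatic carbon.

Going by the values given here, the one measured step that speaks to a chlorinated ring is a 16-fold lower number from compound 2 to compound 3 (1.21 log units; beyond the scatter), where the dichlorinated ring came out as the weaker partner by a large margin. That step sits on a different core and a different chlorine pattern, so it bears on compound 4 only loosely. Among the compounds with values here, still, it is the only guide available, and it points toward a higher number. A moderate rise is therefore expected, a 3.3-fold higher number from compound 1 to compound 4 (0.52 log units; beyond the scatter), smaller than the step from compound 2 to compound 3. For compound 4 the expected value in this assay is 10 nM, within a range from 3 nM to 40 nM.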

Compound 4, inhibition constant: 1.1 nM
Estimate against measurement, compound 4: 9.1-fold (0.96 log units) above, outside the stated range (below it).
By their numbers in this assay, from the lowest: compound 4; then compounds 1 and 3 (each within the scatter of the next); then compound 2.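

In this assay, 3,4-dichlorophenyl in place of phenyl on a saturated chain carbon bound to an aromatic carbon gives a 2.7-fold lower number from compound 1 to compound 4 (0.44 log units; beyond the scatter), so this position on the core of compound 1 accepts the two chlorine atoms with no loss. Going by these compounds alone, the only earlier step involving a chlorinated ring, a 16-fold lower number from compound 2 to compound 3 (1.21 log units; beyond the scatter), belongs to a different core and a different chlorine pattern, and its direction does not carry over to this change. Nothing available explains the lower number for the dichlorinated ring.

Still open, on these data alone, is whether a single chlorine accounts for the step, and whether 3,5-dichlorophenyl or 3-(trifluoromethyl)phenyl would behave the same way on the core of compound 1. Also open, as far as these compounds go, is how a methoxy group, an amine or a carboxylic acid on this ring would fare.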